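Cyanophenyl amide on the cinnamylpiperidine scaffold

The compounds below may be only part of what the source reports. "The series", "measured", "known", "first", "only" and "open" are said of these compounds alone.

Measured compounds:
compound 1, `Cc1ccc(NC(=O)C2CCN(C/C=C/c3ccccc3)CC2)cc1`, 30000 nM
compound 2, `COc1ccccc1NC(=O)C1CCN(C/C=C/c2ccccc2)CC1`, > 100000 nM

Compound 2 sits at the weak end of what has been measured: in a functional assay on MCF7 cells (Homo sapiens) for inhibition, read by MTT assay, with a stated time of 72 h (on this read-out higher numbers stand for weaker inhibition and lower numbers for stronger inhibition), compound 2 reaches only the assay limit, > 100000 nM, which is a limit rather than a number (the limit of > 100000 nM in this assay, at which 1 of the 2 values shown sits). Within the data shown here, compound 1, which carries 4-methylphenyl on the amide-type nitrogen, gives 30000 nM, and the one measured step, an at least 3.3-fold higher number from compound 1 to compound 2 (0.52 log units; beyond the scatter), shows that 2-methoxyphenyl in that place weakens inhibition.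

The next compound, compound 3, `N#Cc1ccc(NC(=O)C2CCN(C/C=C/c3ccccc3)CC2)cc1`, differs from compound 2 by 4-cyanophenyl in place of 2-methoxyphenyl on an amide-type nitrogen. Among the measured compounds shown here, no measured step covers a nitrile, and the only step known here, an at least 3.3-fold higher number from compound 1 to compound 2 (0.52 log units; beyond the scatter), describes the loss of 4-methylphenyl rather than the gain of 4-cyanophenyl. Because compound 1 with 4-methylphenyl gives 30000 nM, a return toward that level is considered possible, but a 4-cyanophenyl amide has not been measured, so the expectation is wide. The step expected is an at least 2.0-fold lower number from compound 2 to compound 3 (0.30 log units; that floor lies within the scatter). For compound 3 the estimate in this assay is 50000 nM, with a range from 15000 nM to 150000 nM.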

Compound 3, half-maximal inhibitory concentration: 44500 nM
Estimate against measurement, compound 3: 1.1-fold (0.05 log units) above; the measured number falls inside the stated range.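

In this assay, the amide-type nitrogen turns out to tolerate a group other than 4-methylphenyl without the loss seen with 2-methoxyphenyl: 4-cyanophenyl in place of 2-methoxyphenyl gives an at least 2.2-fold lower number from compound 2 to compound 3 (0.35 log units; beyond the scatter). Cyano in place of methyl on an aromatic carbon gives a 1.5-fold higher number from compound 1 to compound 3 (0.17 log units; within the scatter), so the nitrile and the methyl group cannot be put in any order at this place, and the two groups leave the compounds at a similar level in this assay. The step from the methoxy compound can be read only as a floor, since compound 2 stands at a limit and not at a number: the limit of > 100000 nM in this assay, at which 1 of the 3 values shown sits.

The compounds shown leave open whether the methoxy group itself goes with the weak result of compound 2, and how an amine, a carboxylic acid or a chlorine atom in place of the nitrile would read in this assay. As far as these compounds go, it also stays open whether a plain phenyl group, with nothing on the ring, would read any differently from compound 1 and compound 3.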